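The source may hold more compounds than are shown below. What is called first, only, known or untested is meant among the compounds shown, and "the series" means these compounds.

Compounds measured so far:

compound 1 `C[C@@H](O[C@@H]1CN(C=O)C[C@H]1c1ccc(F)cc1)c1cc(C(F)(F)F)cc(C(F)(F)F)c1` gives 0.24 nM in an assay on CHO cells for displacement of a labelled ligand from Substance-P receptor (Homo sapiens); on this read-out higher numbers stand for weaker inhibition and lower numbers for stronger inhibition;
compound 2 `CC(=O)N1CCC(C(=O)N2C[C@@H](O[C@H](C)c3cc(C(F)(F)F)cc(C(F)(F)F)c3)[C@H](c3ccc(F)cc3)C2)CC1` gives 0.07 nM in this assay;
compound 3 `CC(C)NC(=O)N1C[C@@H](O[C@H](C)c2cc(C(F)(F)F)cc(C(F)(F)F)c2)[C@H](c2ccc(F)cc2)C1` gives 0.06 nM in this assay.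

Compound 3 has the lowest of the three numbers. Its nearest neighbour is compound 2, separated by a 1.2-fold lower number from compound 2 to compound 3 (0.07 log units; within the scatter), so the two cannot be told apart. Its furthest is compound 1, separated by a 4.0-fold lower number from compound 1 to compound 3 (0.60 log units; beyond the scatter). Compound 4 `C[C@@H](O[C@@H]1CN(C(=O)NC(C)(C)C)C[C@H]1c1ccc(F)cc1)c1cc(C(F)(F)F)cc(C(F)(F)F)c1` has not yet been measured. It differs from compound 3 by methyl in place of hydrogen on a saturated chain carbon bound to an amide-type nitrogen and two saturated chain carbons.

Among the measured compounds shown here, no measured step touches this exact carbon. The steps that come closest all change what sits on the carbonyl carbon: a 3.4-fold lower number from compound 1 to compound 2 (0.54 log units; beyond the scatter) and a 4.0-fold lower number from compound 1 to compound 3 (0.60 log units; beyond the scatter) show that replacing the hydrogen there with a larger group lowers the number modestly, while a 1.2-fold lower number from compound 2 to compound 3 (0.07 log units; within the scatter) shows that two quite different groups on that carbon give numbers that cannot be distinguished. A single added methyl on the chain carbon of the isopropylamino group is a smaller change than either of those, so no step beyond the scatter is expected, in either direction. Compound 4 is therefore estimated at 0.06 nM, within 0.03 nM to 0.13 nM, which means an expected step of no change at the digits printed from compound 3 to compound 4 (within the scatter).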

Compound 4, half-maximal inhibitory concentration: 0.14 nM
Compound 4: middle estimate off by 2.3-fold (0.37 log units), on the low side, and the stated range ends below it.
By their numbers in this assay, from the lowest: compounds 3, 2, 4 and 1 (each within the scatter of the next, the first and the last beyond it).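

In this assay, among the compounds shown here, this is the first measured change at this saturated chain carbon, and it shows that a single added methyl, turning isopropyl into tert-butyl, can move the number beyond the scatter (a 2.3-fold higher number from compound 3 to compound 4 (0.37 log units; beyond the scatter)). It also shows that a larger group on the carbonyl carbon does not always give a step beyond the scatter when it replaces hydrogen: with (tert-butyl)amino the step stays within the scatter (a 1.7-fold lower number from compound 1 to compound 4 (0.23 log units; within the scatter)), and the step from the very different 1-acetylpiperidin-4-yl is also within it (a 2.0-fold higher number from compound 2 to compound 4 (0.30 log units; within the scatter)). Nothing measured here accounts for the effect of the added methyl.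

The compounds shown leave open what a hydroxyl group, a fluorine atom or an ethyl group would do in place of this methyl on the same carbon. They also leave open whether a cyclopropyl ring in place of the whole isopropyl group would give a number closer to that of compound 3 or to that of compound 4.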